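Chain on the saturated carbon bound to the aromatic nitrogen

The source may report more compounds than this note shows. Statements on the series, on what has been measured and on what is new or still open speak of the compounds shown alone.

Compound 3 `Cn1c(=O)n(C2OC(CO)[C@@H](O)[C@H]2O)c2nc(N)nc(O)c21` gives 99% in a functional assay on the whole organism (B cells) with Mus musculus as the target (a higher number here means a larger maximal response, a lower number a smaller maximal response), the highest of the three measured values; compound 2 `CCOC(=O)Cn1c(=O)n(C2OC(CO)[C@@H](O)[C@H]2O)c2nc(N)nc(O)c21` gives 86% and compound 1 `COc1ccc(Cn2c(=O)n(C3OC(CO)[C@@H](O)[C@H]3O)c3nc(N)nc(O)c32)cc1` gives 44%. Compound 4 `CCCCn1c(=O)n(C2OC(CO)[C@@H](O)[C@H]2O)c2nc(N)nc(O)c21` differs from compound 3 by propyl in place of hydrogen on a saturated chain carbon bound to an aromatic nitrogen. For the measured compounds named here, the steps that bear on this are a number 55 percentage points higher from compound 1 to compound 3 (beyond the scatter) and a number 13 percentage points higher from compound 2 to compound 3 (beyond the scatter): both replace a group at this position with hydrogen and both raise the maximal response, the second one modestly. Propyl entering at the same place is therefore expected to lower the response, by a step of a number 19 percentage points lower from compound 3 to compound 4 (beyond the scatter), smaller than either measured step. For compound 4 the estimate in this assay is 80%, with a range from 55% to 100%.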

Compound 4, largest response reached (reported as maximal response), in percent of the reference or control that the assay uses: 86%
Beside the measured number, compound 4's estimate is 6 percentage points below it; the measured number falls inside the stated range.
By their numbers in this assay, from the lowest: compound 1; then compounds 2 and 4 (each within the scatter of the next); then compound 3.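

In this assay, propyl in place of hydrogen at this position gives a number 13 percentage points lower from compound 3 to compound 4 (beyond the scatter), so a plain alkyl chain also lowers the response, as ethoxycarbonyl and 4-methoxyphenyl do. Propyl in place of ethoxycarbonyl gives no change at the digits printed from compound 2 to compound 4 (within the scatter), so these two groups are not told apart here, while propyl in place of 4-methoxyphenyl gives a number 42 percentage points higher from compound 1 to compound 4 (beyond the scatter), leaving the large loss with 4-methoxyphenyl alone among the groups shown. Nothing available explains these steps.

On these data alone, whether a longer chain, an unsubstituted phenyl or a carboxylic acid here would follow propyl or 4-methoxyphenyl remains open.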